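The source may report more compounds than this note shows. Statements on the series, on what has been measured and on what is new or still open speak of the compounds shown alone.

Within the data shown here, in an ADME assay on microsomes from liver (Mus musculus) for metabolic stability, read by LC-MS, with a stated time of 10 min, tested at 0.5 uM (a higher number here means that more of the compound is left, a lower number that less of the compound is left), compound 3 (`NC(=O)N1CCN(CCCN(C[C@H]2Cc3ccccc3CN2)[C@H]2CCCc3cccnc32)CC1`) stands highest at 42% against compound 2 (`c1ccc2c(c1)CN[C@@H](CN(CC[C@@H]1CCCNC1)[C@H]1CCCc3cccnc31)C2`) at 23% and compound 1 (`c1ccc2c(c1)CN[C@@H](CN(CC1CCNCC1)[C@H]1CCCc3cccnc31)C2`) at 13% in the series so far. Compound 4 (`c1ccc2c(c1)CN[C@@H](CN(CCCN1CCN(C3CC3)CC1)[C@H]1CCCc3cccnc31)C2`) has cyclopropyl in place of carbamoyl on an amine nitrogen in a ring. Among the measured compounds shown here, two measured steps bear on this change, each arriving at the 4-carbamoylpiperazin-1-yl group: a number 19 percentage points higher from compound 2 to compound 3 (beyond the scatter) and a number 29 percentage points higher from compound 1 to compound 3 (beyond the scatter) in the same direction. For the measured compounds named here, no measured compound has cyclopropyl, and none isolates carbamoyl, so the guide is loose. Part of those steps is expected to be lost, a modest fall in this assay (a number 12 percentage points lower from compound 3 to compound 4 (beyond the scatter)). The expected value for compound 4 is 30% within an estimated range (14% to 47%).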

Compound 4, percent of the compound remaining: 3%
Beside the measured number, compound 4's estimate is 27 percentage points above it, outside the stated range (below it).
By their numbers in this assay, from the lowest: compounds 4, 1 and 2 (each within the scatter of the next, the first and the last beyond it); then compound 3.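

In this assay the carbamoyl on the ring amine nitrogen matters, not the ring alone: cyclopropyl there gives a number 39 percentage points lower from compound 3 to compound 4 (beyond the scatter). The 4-cyclopropylpiperazin-1-yl group also gives a number 20 percentage points lower from compound 2 to compound 4 (beyond the scatter) and shows a number 10 percentage points lower from compound 1 to compound 4 (within the scatter), so it offers no clear gain over piperidin-4-yl. No evidence on the cause of this loss is at hand. From the compounds shown here alone, whether acetyl or methyl on that nitrogen would stay near compound 3 remains open.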